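Swapping 3-bromophenyl for 1,3-thiazol-2-yl on the amide nitrogen

A few compounds are considered here, and "the series" means these few. Any claim that something is new, unique, unknown or untested is made for them only; others in the source may bear on it.

Measured in a functional assay on MGC-803 cells (Homo sapiens) for inhibition, read by MTT assay, with a stated time of 72 h; a higher number here means a weaker inhibitor, a lower number a stronger inhibitor
- compound 1 `CCc1ccc(NC(=O)C2CCN(C/C=C/c3ccccc3)CC2)cc1` at 11600 nM
- compound 2 `O=C(Nc1cccc(Br)c1)C1CCN(C/C=C/c2ccccc2)CC1` at 9110 nM

Compound 2 at 9110 nM sits within the scatter of compound 1, so the pair cannot be separated. Compound 3 `O=C(Nc1nccs1)C1CCN(C/C=C/c2ccccc2)CC1` carries 1,3-thiazol-2-yl in place of 3-bromophenyl on an amide-type nitrogen, counted as 1,3-thiazol-2-yl in place of 3-bromophenyl on an amide-type nitrogen in full. For the measured compounds named here, the only measured step, a 1.3-fold lower number from compound 1 to compound 2 (0.10 log units; within the scatter) on that same kind of nitrogen, stays within the scatter. Going by the values given here, no measured step covers a five-membered aromatic ring with 2 hetero atoms, so no direction can be set in this assay and no shift beyond the scatter is expected. The expected step is a 1.1-fold higher number from compound 2 to compound 3 (0.04 log units; within the scatter) at the middle of the estimate. For compound 3 the estimated value is 10000 nM within an expected range of 3500 nM to 30000 nM for repeat measurements.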

Compound 3, half-maximal inhibitory concentration: 16400 nM
Compound 3: the middle estimate sits 1.6-fold (0.21 log units) below what was measured; the measured number falls inside the stated range.
By their numbers in this assay, from the lowest: compounds 2, 1 and 3 (each within the scatter of the next).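

In this assay, a five-membered aromatic ring with 2 hetero atoms on the amide-type nitrogen reads no differently from the six-membered carbon-only rings: a 1.8-fold higher number from compound 2 to compound 3 (0.26 log units; within the scatter), and a 1.4-fold higher number from compound 1 to compound 3 (0.15 log units; within the scatter). So the change from 0 to 2 hydrogen-bond acceptors in this group, with fewer heavy atoms, gives no step beyond the scatter. No supporting measurement bears on this result.

Still open, going by these compounds, is whether any group here can move the number beyond the scatter, such as a carboxylic acid, an amine or a longer chain. On these data alone, the shared core stays fixed throughout, so its contribution remains unknown.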